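A few compounds are considered here, and "the series" means these few. Any claim that something is new, unique, unknown or untested is made for them only; others in the source may bear on it.

Of the compounds shown here, three have so far been measured in an ADME assay for permeability, using PAMPA, at pH 7.4; on this read-out lower numbers stand for lower permeability and higher numbers for higher permeability. Compound 1 `Cc1[nH]c2ccc(Cl)cc2c(=O)c1Cc1ccccc1` gives 415 10^-6 cm/s in this assay. Compound 3 `Cc1c(Cc2ccccc2)c(=O)c2cc(Cl)ccc2n1C` carries the change methyl in place of hydrogen on an aromatic nitrogen relative to compound 1, and in this assay compound 3 gives 489 10^-6 cm/s; the step of a 1.2-fold higher number from compound 1 to compound 3 (0.07 log units; within the scatter) shows what this change did here. Compound 2 `COc1ccc2c(=O)c(Cc3ccccc3)c(C)[nH]c2c1` rests on a different core, and how the core of compound 2 differs from the core of compound 1 is not broken down here. In this assay compound 2 gives 240 10^-6 cm/s, the lowest of the three numbers, within the scatter of compound 1 and beyond the scatter of compound 3. Compound 4 `COc1ccc2c(=O)c(Cc3ccccc3)c(C)n(C)c2c1` is not yet measured; it stands to compound 2 as compound 3 stands to compound 1, with methyl in place of hydrogen on an aromatic nitrogen the same change at the same place. The expected step is a 1.2-fold higher number from compound 2 to compound 4 (0.08 log units; within the scatter), set beside the earlier one and resting on the step of a 1.2-fold higher number from compound 1 to compound 3 (0.07 log units; within the scatter) that stayed within the scatter. Compound 4 is therefore estimated at 290 10^-6 cm/s in this assay, with a range from 170 10^-6 cm/s to 500 10^-6 cm/s.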

Compound 4, apparent permeability: 299 10^-6 cm/s
Beside the measured number, compound 4's estimate is 1.0-fold (0.01 log units) below it; measured number inside the range.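

In this assay, methyl in place of hydrogen on an aromatic nitrogen gives a 1.2-fold higher number from compound 2 to compound 4 (0.10 log units; within the scatter), and the change reads alike on the two cores: the same change on two cores in this assay, a 1.2-fold higher number (0.07 log units; within the scatter) from compound 1 to compound 3 and a 1.2-fold higher number (0.10 log units; within the scatter) from compound 2 to compound 4, 1.1-fold (0.02 log units) apart, within the scatter of two such steps Carried from the core of compound 1 to the core of compound 2, the step therefore kept its size as far as these measurements can tell, but neither step lies beyond the scatter, so what carries over is a step too small to tell apart from repeat measurements, not a firm rise. Two pairs also do not show that the same would hold on other cores of this series.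

The compounds shown leave open whether a longer chain on that aromatic nitrogen, such as ethyl or a chain ending in an amine, would stay as close to the hydrogen compound in this assay. They also leave open whether the methyl step would read the same on a core carrying a carboxylic acid.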